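Swapping Propoxy for Butyl on the Shared Core

A few compounds are considered here, and "the series" means these few. Any claim that something is new, unique, unknown or untested is made for them only; others in the source may bear on it.

Of the compounds shown here, three built on one shared core have been tested in a functional assay on the whole organism with Rattus norvegicus as the target, at a dose of 1 mg/kg by the oral route; on this read-out higher numbers stand for a stronger effect at the one dose given and lower numbers for a weaker effect. Compound 1 `CCCc1ccc(-c2cc(Cl)cc(C(=O)Nc3nn[nH]n3)n2)cc1` gives 78%, compound 3 `Cc1ccc(-c2cc(C)cc(C(=O)Nc3nn[nH]n3)n2)cc1` gives 80%, and compound 2 `CCCOc1cc(C(=O)Nc2nn[nH]n2)nc(-c2ccc(N)cc2)c1` gives 64%, the lowest of the three, with both other numbers higher by more than the usual scatter. Compound 4 `CCCCc1cc(C(=O)Nc2nn[nH]n2)nc(-c2ccc(N)cc2)c1` is not yet measured; it differs from compound 2 in one place: butyl in place of propoxy on an aromatic carbon. Among the compounds with values here, no two measured compounds differ in just one place, so no step of this exact kind is known. Since compounds 1 and 3 sit higher, a modest rise is expected, though none beyond the scatter is equally possible. Compound 4 is estimated at 70%, ranging from 50% to 88%. The expected step is a number 6 percentage points higher from compound 2 to compound 4 (within the scatter), within the scatter.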

Compound 4, a percentage reported as inhibition, in the whole organism at one dose (the size of the read-out at that dose, not a potency): 81%
Compound 4: the middle estimate sits 11 percentage points below what was measured, and the stated range covers the measured number.
By their numbers in this assay, from the lowest: compound 2; then compounds 1, 3 and 4 (each within the scatter of the next).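

In this assay this position proves sensitive to a single change: butyl in place of propoxy brings a number 17 percentage points higher from compound 2 to compound 4 (beyond the scatter) on the shared core, with the 4-aminophenyl group unchanged. Both chains have the same count of heavy atoms, so the rise comes with a carbon taking the place of an oxygen, not with a larger group. Nothing measured here explains the rise. The compounds shown leave open how a longer chain such as hexyl, or an amine, would read at this position, and whether butyl gives the same rise with a different group in place of 4-aminophenyl.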